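A few compounds are considered here, and "the series" means these few. Any claim that something is new, unique, unknown or untested is made for them only; others in the source may bear on it.

Measured compounds:
compound 1, `COC(=O)CC/C=C\CC[C@H]1C(=O)C[C@@H](O)[C@@H]1/C=C/C[C@@](C)(O)/C=C/C(C)=C(C)C`, > 3.16 mg/kg
compound 2, `CCCCC(C)(O)C/C=C/[C@H]1[C@H](O)CC(=O)[C@@H]1CC/C=C\CCC(=O)OC`, 0.049 mg/kg

Compound 1 stands at a limit of a functional assay on the whole organism with Rattus norvegicus as the target (a lower number here means that less compound is needed, a higher number that more compound is needed for the effect), rather than at a number: the value given for compound 1 is the limit of > 3.16 mg/kg in this assay, at which 1 of the 2 values shown sits, so its true position is known only as a bound. Compound 2, by contrast, gives 0.049 mg/kg in this assay. Going by the values given here, the one measured step, an at least 64-fold lower number from compound 1 to compound 2 (1.80 log units; beyond the scatter), shows that exchanging the whole 1-hydroxy-1,4,5-trimethylhexa-2,4-dien-1-yl chain for a shorter saturated one is linked to a far lower number.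

Compound 3, `C/C=C/C=C/[C@](C)(O)C/C=C/[C@H]1[C@H](O)CC(=O)[C@@H]1CC/C=C\CCC(=O)OC`, is not yet measured. It differs from compound 1 by prop-1-en-1-yl in place of 1,2-dimethylprop-1-en-1-yl on a double-bonded chain carbon bound to a double-bonded chain carbon, so it keeps the diene of compound 1 but loses two methyl carbons at its far end. The step from compound 1 to compound 2 bears on it only in part, as it changed the same chain more deeply and, with compound 1 at a limit, its size is a minimum. Among the compounds with values here, a step of at least an at least 3.1-fold lower number from compound 1 to compound 3 (0.49 log units; beyond the scatter) toward a lower number is therefore expected for compound 3, though smaller than the one to compound 2. Compound 3 is estimated at 1 mg/kg, within 0.1 mg/kg to 10 mg/kg.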

Compound 3, dose for half-maximal effect: 0.25 mg/kg
Beside the measured number, compound 3's estimate is 4.0-fold (0.60 log units) above it, and the stated range covers the measured number.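

The exchange of 1,2-dimethylprop-1-en-1-yl for prop-1-en-1-yl alone, on a double-bonded chain carbon bound to a double-bonded chain carbon, gives an at least 12-fold lower number from compound 1 to compound 3 (1.10 log units; beyond the scatter) in this assay, so a change much smaller than replacing the whole chain is enough for a large step at this position. The diene as such is therefore compatible with a low number, although it does not match the saturated chain: 1-hydroxy-1-methylhexa-2,4-dien-1-yl in place of 1-hydroxy-1-methylpentyl gives a 5.1-fold higher number from compound 2 to compound 3 (0.71 log units; beyond the scatter), a modest step. The true size of the first of these steps remains a minimum, because compound 1 stands at a limit: the limit of > 3.16 mg/kg in this assay, at which 1 of the 3 values shown sits.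

The compounds shown leave open whether a single methyl on the 1,2-dimethylprop-1-en-1-yl group would be enough to account for the large step, as no compound carries just one of them. They also leave open how a phenyl group or a longer chain in place of prop-1-en-1-yl would stand in this assay, and whether a carboxylic acid in place of the methyl ester would keep these numbers.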